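The compounds below may be only part of what the source reports. "The series", "measured", "known", "first", "only" and "open" are said of these compounds alone.

Compound 1 `COc1cc(/C=C/C(=O)c2cccc(-n3cc(-c4ccc(Cl)cc4)[nH]c3=O)c2)cc(OC)c1OC` is one of two compounds tested in a functional assay on UACC-257 cells (Homo sapiens) for inhibition (on this read-out lower numbers stand for stronger inhibition of growth and higher numbers for weaker inhibition of growth), where compound 1 gives 17400 nM. This is the higher of the two numbers. Its neighbour, compound 2 `O=C(/C=C/c1cccc(O)c1)c1cccc(-n2cc(-c3ccc(Cl)cc3)[nH]c2=O)c1`, has a hydroxyphenyl group in place of the trimethoxyphenyl on the enone side; in this assay compound 2 gives 4070 nM, and the gap between the two values lies beyond the scatter. Compound 3 `COc1cc(/C=C/C(=O)c2cccc(-n3cc(-c4cc(OC)c(OC)c(OC)c4)[nH]c3=O)c2)cc(OC)c1OC` has not yet been measured. It keeps the shared core of compound 1 but carries a different aromatic group on the five-membered ring: 3,4,5-trimethoxyphenyl in place of 4-chlorophenyl on an aromatic carbon. Among the measured compounds shown here, no measured pair shows what this change does on its own, so the size and direction of its effect cannot be read from the two numbers in hand. A change of modest size in either direction, or none beyond the scatter, is expected, and the step from compound 1 to compound 3 is estimated at a 1.5-fold lower number from compound 1 to compound 3 (0.16 log units; within the scatter). Compound 3 is therefore expected to give about 12000 nM in this assay, within a range from 3000 nM to 50000 nM.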

Compound 3, concentration for 50% growth inhibition: 2220 nM
Beside the measured number, compound 3's estimate is 5.4-fold (0.73 log units) above it; measured number outside the range, below it.
By their numbers in this assay, from the lowest: compounds 3 and 2 (each within the scatter of the next); then compound 1.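

In this assay, the aromatic group on the five-membered ring proves to matter on its own: 3,4,5-trimethoxyphenyl in place of 4-chlorophenyl gives a 7.8-fold lower number from compound 1 to compound 3 (0.89 log units; beyond the scatter). The earlier compounds shown here held this group constant, whereas this pair shows that the position accepts the larger group, which brings hydrogen-bond acceptors absent from 4-chlorophenyl, with stronger rather than weaker inhibition of growth. Nothing available explains this gain.

The pair cannot separate the loss of the chlorine from the arrival of the methoxy groups, and simple phenyl or 4-methoxyphenyl at this position would bear on that question. It also leaves open whether the same exchange would have a similar effect alongside the hydroxyphenyl group of compound 2.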